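Swapping the sulfonyl aryl group for a benzyl group

The source may report more compounds than this note shows. Statements on the series, on what has been measured and on what is new or still open speak of the compounds shown alone.

Compound 1 `COc1ccc(-c2c(Br)c(=O)c3c(OC)cc(OC)cc3n2S(=O)(=O)c2ccc(OC)cc2)cc1`: 2920 nM
Compound 2 `COc1ccc(-c2cc(=O)c3c(OC)cc(OC)cc3n2S(=O)(=O)c2cccc([N+](=O)[O-])c2)cc1`: a limit only, > 39600 nM

In a functional assay on SUP-B15 cells (Homo sapiens) for antiproliferative activity, with a stated time of 72 h (a lower number here means that less compound is needed, a higher number that more compound is needed for the effect), compound 2 gives no number but a limit, > 39600 nM; (the limit of > 39600 nM in this assay, at which 1 of the 2 values shown sits). Compound 2 therefore stands at the edge of what this assay can report. Compound 3 `COc1ccc(-c2cc(=O)c3c(OC)cc(OC)cc3n2S(=O)(=O)Cc2ccccc2)cc1` differs from compound 2 in one place: benzyl in place of 3-nitrophenyl on a sulfonyl sulfur. Among the compounds with values here, no measured pair of this kind exists here, so the size and direction of the step in this assay cannot be read from the data; a change either way, or none beyond the scatter, is possible. Compound 3 is estimated at 25000 nM in this assay, within 5000 nM to 100000 nM. The expected step, an at least 1.5-fold lower number from compound 2 to compound 3 (0.19 log units; that floor lies within the scatter), rests on a limit rather than a number.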

Compound 3, half-maximal effective concentration: > 34400 nM
Compound 3: a limit, no number; the forecaster's own chance of this, stated with the estimate: 50%; at least 1.3-fold (0.13 log units) between middle value and limit.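

Within the data shown here, compound 2 and compound 3 each give only a limit, not a number, and no step between them can be read. On these data alone, whether benzyl or 3-nitrophenyl on the sulfonyl sulfur gives the lower number stays open.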